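A few compounds are considered here, and "the series" means these few. Any claim that something is new, unique, unknown or untested is made for them only; others in the source may bear on it.

Working notes on the series. Compound 1 `Fc1ccc(-c2nnc3nnc(N4CCCC4)n3n2)cc1` is held at the limit of the assay: in a functional assay on MCF7 cells (Homo sapiens) for cytotoxicity, read by MTT assay, with a stated time of 72 h (a lower number here means a stronger inhibitor, a higher number a weaker inhibitor), compound 1 gives > 100000 nM, which is a limit and not a number. Compound 3 `c1ccc(-c2nnc3nnc(N4CCCC4)n3n2)cc1` likewise reaches only a limit in this assay, at > 100000 nM. Within the data shown here, the one measured step, a step that the two limits leave unreadable from compound 1 to compound 3, therefore cannot be sized, because both of its ends sit at the limit of > 100000 nM in this assay, at which 2 of the 3 values shown sit.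

Among the measured compounds shown here, compound 2 `CC(C)(C)c1nnc2nnc(N3CCCC3)nn12` is the only member with a number in this assay: compound 2 gives 55000 nM. It stands as the sole numeric point of the three, the other two values being limits, so no ordering within the set can be read from it.

Compound 4 `CC(C)c1nnc2nnc(N3CCCC3)nn12` is not yet measured. It differs from compound 2 by hydrogen in place of methyl on a saturated chain carbon bound to an aromatic carbon and two saturated chain carbons, the same difference read one bond further out being tert-butyl to isopropyl. For the measured compounds named here, no measured step bears on this change; the only measured step concerns a substituent on an aromatic carbon and its size is hidden by the limits. With nothing to point either way, the step from compound 2 to compound 4 is expected to be a 1.3-fold higher number from compound 2 to compound 4 (0.10 log units; within the scatter), not beyond the usual scatter and with no direction. Compound 4 is therefore estimated at 70000 nM, in the range 25000 nM to 200000 nM, with a real chance that this assay again reports only a limit.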

Compound 4, half-maximal inhibitory concentration: 46800 nM
Estimate against measurement, compound 4: 1.5-fold (0.17 log units) above, and the stated range covers the measured number.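

In this assay the change from tert-butyl to isopropyl gives the series its first step with a readable size: a 1.2-fold lower number from compound 2 to compound 4 (0.07 log units; within the scatter). Among these compounds, the change sits on a saturated chain carbon bound to an aromatic carbon and two saturated chain carbons, and it is the first evidence on this position, where swapping one methyl for hydrogen leaves the two compounds indistinguishable in this assay. Among the compounds shown here, both ends of this step carry numbers rather than limits, which the one earlier step did not offer, so tert-butyl and isopropyl can be treated as equivalent here, on this single pair only.

The compounds shown leave open whether an amine, a carboxylic acid or a longer chain such as n-butyl in this place would move the number beyond the scatter, as neither step read so far spans more than a single small change in a carbon group. The effect of hydrogen in place of fluoro on an aromatic carbon also stays unsized, because both of its ends sit at a limit: the limit of > 100000 nM in this assay, at which 2 of the 4 values shown sit.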